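The compounds below may be only part of what the source reports. "The series", "measured", "known", "first", "only" and "open" are said of these compounds alone.

Measured in a functional assay on DU-145 cells (Homo sapiens) for inhibition, read by trypan blue exclusion, with a stated time of 72 h; a lower number here means a stronger inhibitor, a higher number a weaker inhibitor:
Compound 1 `Cn1c(=O)c(S(=O)(=O)c2ccc(Cl)cc2Cl)cc2cnc(Nc3ccc4[nH]ccc4c3)nc21`: 1000 nM
Compound 2 `Cn1c(=O)c(S(=O)(=O)c2ccc(F)cc2)cc2cnc(Nc3ccc4[nH]ccc4c3)nc21`: 300 nM

Of these two numbers, compound 2 has the lower, 300 nM, which makes it the stronger inhibitor of the pair. The next compound, compound 3 `Cn1c(=O)c(S(=O)(=O)c2ccc(O)cc2)cc2cnc(Nc3ccc4[nH]ccc4c3)nc21`, has hydroxy in place of fluoro on an aromatic carbon, para to a large group: hydroxy in place of fluoro on an aromatic carbon. Within the data shown here, only one measured step bears on this change: a 3.3-fold lower number from compound 1 to compound 2 (0.52 log units; beyond the scatter). That step also alters the phenyl group on the sulfonyl sulfur, and it was modest. Among the measured compounds shown here, no measured compound carries a hydroxy group, so the data give no direction for this change. A step of no more than similar size is therefore expected in this assay, quite possibly within the scatter. The expected change is a 1.2-fold higher number from compound 2 to compound 3 (0.07 log units; within the scatter). For compound 3 the estimated value is 350 nM, with an expected range from 100 nM to 1200 nM.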

Compound 3, half-maximal inhibitory concentration: 250 nM
The estimate for compound 3 lay 1.4-fold (0.15 log units) above the measured number, within the range that was stated.
By their numbers in this assay, from the lowest: compounds 3 and 2 (each within the scatter of the next); then compound 1.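

In this assay, hydroxy in place of fluoro on this aromatic carbon, para to a large group, gives a 1.2-fold lower number from compound 2 to compound 3 (0.08 log units; within the scatter), so the two compounds cannot be told apart here, even though hydroxy counts a hydrogen-bond donor and a hydrogen-bond acceptor and fluoro counts neither. The change from the 2,4-dichlorophenyl group to the 4-hydroxyphenyl group gives a 4.0-fold lower number from compound 1 to compound 3 (0.60 log units; beyond the scatter), so a second group at this position also gives a lower number than the dichlorinated ring does. No supporting measurement is available to explain why this swap makes so little difference.

From the compounds shown here alone, it remains open whether an amine, a carboxylic acid or a methoxy group at this position would fit the same picture. A 4-chlorophenyl group would help show whether the higher number of compound 1 goes with one particular chlorine or with the pair.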